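Capping the remaining hydroxy of compound 2

The compounds below may be only part of what the source reports. "The series", "measured", "known", "first", "only" and "open" are said of these compounds alone.

In a functional assay on MCF7 cells (Homo sapiens) for inhibition, read by MTT assay, with a stated time of 2 days (a lower number here means a stronger inhibitor, a higher number a weaker inhibitor), compound 1 (`Oc1cccc(/C=C/c2cccc(O)c2)c1`) gives 21 ug/mL. Compound 2 (`Nc1cccc(/C=C/c2cccc(O)c2)c1`) gives 54 ug/mL, the higher of the two numbers, which makes it the weaker inhibitor of this pair.

Compound 3 (`COc1cccc(/C=C/c2cccc(N)c2)c1`) keeps the amino group of compound 2 but turns its hydroxy into methoxy. This places methyl in place of hydrogen on an oxygen on an aromatic ring. Going by the values given here, no measured step shows this exact change, so any forecast rests on thin evidence. Among the compounds with values here, the only guide is the step of a 2.6-fold higher number from compound 1 to compound 2 (0.41 log units; beyond the scatter), a modest move beyond the scatter, made by putting amino in place of hydroxy on an aromatic carbon. That step also removed a hydroxy and raised the number, so a small rise in the same direction seems the likeliest outcome here, though it may stay within the scatter. The expected change in this assay is a 1.4-fold higher number from compound 2 to compound 3 (0.14 log units; within the scatter). For compound 3 the estimated value is 75 ug/mL, with an expected range from 25 ug/mL to 190 ug/mL.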

Compound 3, half-maximal inhibitory concentration: 34 ug/mL
Beside the measured number, compound 3's estimate is 2.2-fold (0.34 log units) above it; low and high end bracket the measured number.
By their numbers in this assay, from the lowest: compounds 1, 3 and 2 (each within the scatter of the next, the first and the last beyond it).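

In this assay methyl in place of hydrogen on an oxygen on an aromatic ring gives a 1.6-fold lower number from compound 2 to compound 3 (0.20 log units; within the scatter) and so this pair cannot be told apart by this measurement. Going by these compounds alone, this is the first look at the hydroxy of compound 2, and it shows that the hydrogen on that oxygen can be exchanged for methyl without a shift that stands clear of ordinary repeat-to-repeat variation, unlike the earlier exchange of hydroxy for amino, which gave a 2.6-fold higher number from compound 1 to compound 2 (0.41 log units; beyond the scatter) and lay beyond the scatter. Nothing available here explains why the methyl group leaves the number so little moved.

The compounds shown leave open how much room there is at this oxygen: a longer chain such as ethoxy or butoxy, or an acetyl group in place of the methyl, might behave like methoxy or might not. They also leave open whether the amino group that compound 2 and compound 3 share can be capped in the same way, for instance with a methyl or an acetyl group on its nitrogen.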